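From methoxycarbonyl to acetyl on the shared core

The compounds below may be only part of what the source reports. "The series", "measured", "known", "first", "only" and "open" are said of these compounds alone.

Measured in a functional assay on the whole organism for positive allosteric modulation, with Mus musculus as the target; on this read-out higher numbers stand for an effect only at larger amounts of compound and lower numbers for an effect already at smaller amounts:
- compound 1 `CCC(=O)N(c1ccc(C(F)(F)F)cc1)C1CCCC1N(C)C`: 10 mg/kg
- compound 2 `CCC(=O)N(c1ccc(C(=O)OC)cc1)C1CCCC1N(C)C`: > 50 mg/kg (a limit, not a number)

Compound 2 has no number of its own and stands only at the limit of > 50 mg/kg in this assay, at which 1 of the 2 values shown sits, on this scale. Compound 3 `CCC(=O)N(c1ccc(C(C)=O)cc1)C1CCCC1N(C)C` has not yet been measured. It differs from compound 2 by methyl in place of methoxy on a carbonyl carbon, that is, methoxycarbonyl to acetyl (methyl in place of methoxy on a carbonyl carbon). Going by the values given here, one measured step bears on this change (an at least 5.0-fold higher number from compound 1 to compound 2 (0.69 log units; beyond the scatter)), and it is the step that brought in the methoxycarbonyl. Acetyl keeps the carbonyl on the aromatic carbon, so compound 3 is expected to remain near the limit of compound 2, with no shift beyond the scatter. The expected outcome is a number no higher from compound 2 to compound 3 (the limit leaves the size open) in this assay, although the assay may again report only a limit. For compound 3 the estimate is 50 mg/kg (expected range 20 mg/kg to 100 mg/kg).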

Compound 3, dose for half-maximal effect: > 50 mg/kg
Compound 3 was reported as a limit; the forecaster's own chance of this, stated with the estimate: 55%; the middle value lies on the limit itself.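

In this assay, acetyl in place of trifluoromethyl on an aromatic carbon gives an at least 5.0-fold higher number from compound 1 to compound 3 (0.69 log units; beyond the scatter), so the step away from compound 1 is no longer tied to methoxycarbonyl alone and also holds for a second carbonyl group on this carbon. Compound 3 gives > 50 mg/kg, which is a limit and not a number. Compound 2 also stands at a limit, so the step between them, methyl in place of methoxy on a carbonyl carbon, cannot be read, and the two compounds cannot be ordered.

Going by these compounds, how far the true values of compound 2 and compound 3 lie beyond the limit stays open. On these data alone, it is also open whether a nitrile or a primary amide on this aromatic carbon would come back towards compound 1, at 10 mg/kg.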